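Endothelial lipase series: benzyloxy extension from compound 2

The source may report more compounds than this note shows. Statements on the series, on what has been measured and on what is new or still open speak of the compounds shown alone.

Measured so far:
compound 1, `CCN1CC(C(=O)N[C@H]2CC[C@@H](c3ccccc3)CC2)=C(O)C1=O`: 82 nM
compound 2, `Nc1c(C(=O)N[C@H]2CC[C@@H](c3ccccc3)CC2)[nH]c(=O)[nH]c1=O`: 91 nM

In an assay on cells for inhibition of endothelial lipase (Homo sapiens), read by LC-MS, with stated times of 10 min and 30 min (on this read-out higher numbers stand for weaker inhibition and lower numbers for stronger inhibition), compound 1 gives 82 nM and compound 2 gives 91 nM. Compound 2 holds the higher of the two numbers, but the gap to compound 1 is within the scatter of this assay, so the two compounds cannot be told apart on these data. Going by the values given here, the two differ in the core rather than in one place, so no single step between them is counted.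

The next compound, compound 3, is `Nc1c(C(=O)N[C@H]2CC[C@@H](c3ccc(OCc4ccccc4)cc3)CC2)[nH]c(=O)[nH]c1=O`. It keeps the core and the amide of compound 2 and differs only in benzyloxy in place of hydrogen on an aromatic carbon. Among the compounds with values here, no measured pair in this set shows what such an addition does, so the expectation rests on compound 2 alone, with a wide range around it. Compound 3 is expected to land near compound 2 or somewhat lower, because compound 2 gives 91 nM and nothing measured argues for a large move either way. The expected step of a 1.5-fold lower number from compound 2 to compound 3 (0.18 log units; within the scatter) is modest. Compound 3 is estimated at 60 nM, within 15 nM to 250 nM.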

Compound 3, half-maximal inhibitory concentration: 21 nM
Beside the measured number, compound 3's estimate is 2.9-fold (0.46 log units) above it; the range from low to high includes it.
By their numbers in this assay, from the lowest: compound 3; then compounds 1 and 2 (each within the scatter of the next).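

In this assay, the aromatic carbon para to a large group accepts substitution: benzyloxy in place of hydrogen gives a 4.3-fold lower number from compound 2 to compound 3 (0.64 log units; beyond the scatter), which is beyond the scatter. Going by these compounds alone, this is the first step that changes one place only, and it shows that this position is not limited to hydrogen, since a group of 8 heavy atoms carrying a second six-membered aromatic ring lowers the number rather than raising it. No measurement here bears on why the number falls.

A single substituent cannot separate the contribution of the ether oxygen from that of the added ring, and neither methoxy, a plain benzyl group, a longer chain ending in the same ring, nor an amine or a carboxylic acid on the added ring appears among the compounds shown. On these data alone, it also remains open whether benzyloxy at this position would give a similar step on the core of compound 1, and whether other positions on the same aromatic ring would accept the group as well.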